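Swapping the aryl ketone of compound 1 for a pyrazolone

This account rests on a few compounds, and the source may have more. Where it says the series, first, only, none or still open, it means among the compounds named here.

Measured compounds:
compound 1, `O=C(CSCc1nc2cc([N+](=O)[O-])ccc2[nH]1)c1ccc(Cl)cc1`, 2800 nM
compound 2, `O=C(CSCc1nc2cc([N+](=O)[O-])ccc2[nH]1)NNC(=S)Nc1ccccc1`, > 100000 nM

In a functional assay on MCF7 cells (Homo sapiens) for cytotoxicity, read by MTT assay, with a stated time of 48 h (a higher number here means a weaker inhibitor, a lower number a stronger inhibitor), compound 1 gives 2800 nM. Compound 2 gives only a limit of the assay, > 100000 nM, and no number. For the measured compounds named here, compound 1 therefore stands as the only compound with a numerical value, while the other result sits at the limit of > 100000 nM in this assay, at which 1 of the 2 values shown sits. Compound 3, `CC1=NN(C(=O)CSCc2nc3cc([N+](=O)[O-])ccc3[nH]2)C(=O)C1`, has not yet been tested. It differs from compound 1 by a group of 7 heavy atoms (4 carbon, 2 nitrogen, 1 oxygen; one five-membered non-aromatic ring with 2 hetero atoms) in place of a group of 7 heavy atoms (6 carbon, 1 chlorine; one six-membered aromatic ring of carbon only), on a carbonyl carbon. Going by the values given here, no measured pair shows this step. In this assay the step from compound 1 to compound 3 is expected to be a 7.1-fold higher number from compound 1 to compound 3 (0.85 log units; beyond the scatter), a loss beyond the scatter, given that compound 2 reached only the limit > 100000 nM. Compound 3 is thus estimated at 20000 nM, between 5000 nM and 100000 nM.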

Compound 3, half-maximal inhibitory concentration: 8070 nM
Compound 3: the middle estimate sits 2.5-fold (0.39 log units) above what was measured, and the stated range covers the measured number.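

With compound 3, the position on the carbonyl carbon gains its first numerical comparison in this assay: the step is a 2.9-fold higher number from compound 1 to compound 3 (0.46 log units; beyond the scatter), a loss labelled modest. The 4-chlorophenyl group can therefore give way to a five-membered non-aromatic ring with 2 hetero atoms, with two more hydrogen-bond acceptors counted, and the compound still gives a number in the low micromolar range rather than a limit of the assay. Compound 2, also changed at this carbonyl, stands only as a limit and not a number: the limit of > 100000 nM in this assay, at which 1 of the 3 values shown sits.

The compounds shown do not separate the loss of the chlorine from the loss of the aromatic ring, so a plain phenyl group on the same carbonyl carbon would be the telling comparison. They also leave open how an amine or a carboxylic acid on the five-membered ring would fare.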